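Replacing Cyclopropyl with 4-Methylphenyl on the Sulfonyl Sulfur

The source may report more compounds than this note shows. Statements on the series, on what has been measured and on what is new or still open speak of the compounds shown alone.

Three compounds share one core and differ only in the group on an amine nitrogen in a ring. In a functional assay on NCI-H1975 cells (Homo sapiens) for inhibition, read by sulforhodamine B assay, tested at 10 uM (on this read-out higher numbers stand for more inhibition at the one concentration tested (going by the name of the read-out) and lower numbers for less inhibition), compound 1 `CC(=O)N1N=C(c2ccc(N3CCN(C)CC3)cc2)CC1c1ccc(N(C)C)cc1` gives -1.9%; compound 2 `CN1CCN(c2ccc(C3=NN(S(C)(=O)=O)C(c4ccc(N(C)C)cc4)C3)cc2)CC1` gives -1.3%; compound 3 `CN1CCN(c2ccc(C3=NN(S(=O)(=O)C4CC4)C(c4ccc(N(C)C)cc4)C3)cc2)CC1` gives 0.2%. Compound 3 holds the highest of the three numbers, yet both steps to it stay within the scatter: a number 2.1 percentage points higher from compound 1 to compound 3 (within the scatter) and a number 1.5 percentage points higher from compound 2 to compound 3 (within the scatter). Compound 4 `Cc1ccc(S(=O)(=O)N2N=C(c3ccc(N4CCN(C)CC4)cc3)CC2c2ccc(N(C)C)cc2)cc1` is not yet measured; it differs from compound 3 as 4-methylphenyl in place of cyclopropyl on a sulfonyl sulfur. The step that bears on this change is a number 1.5 percentage points higher from compound 2 to compound 3 (within the scatter), an exchange on the same sulfonyl sulfur that moved nothing beyond the scatter. For the measured compounds named here, no measured compound carries an aromatic group there, so an effect cannot be ruled out. Compound 4 is expected to show a number 1.8 percentage points higher from compound 3 to compound 4 (within the scatter), an estimated 2% with a range of -10% to 16%.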

Compound 4, a percentage reported as inhibition, at one concentration (the size of the read-out at that concentration, not a potency): 38.1%
The estimate for compound 4 lay 36.1 percentage points below the measured number; the whole stated range lies below it.
By their numbers in this assay, from the lowest: compounds 1, 2 and 3 (each within the scatter of the next); then compound 4.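

In this assay, the group on the sulfonyl sulfur turns out to matter: cyclopropyl in place of methyl had stayed within the scatter, but 4-methylphenyl in place of cyclopropyl does not (a number 37.9 percentage points higher from compound 3 to compound 4 (beyond the scatter)). The same holds for 4-methylphenyl in place of methyl (a number 39.4 percentage points higher from compound 2 to compound 4 (beyond the scatter)) and for (4-methylphenyl)sulfonyl in place of acetyl (a number 40 percentage points higher from compound 1 to compound 4 (beyond the scatter)). No evidence is available that accounts for this rise. Going by these compounds, it remains open whether the aromatic ring alone suffices or its methyl is also needed. Phenyl, 4-methoxyphenyl, 4-chlorophenyl or benzyl on the same sulfur would bear on this.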